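The compounds below may be only part of what the source reports. "The series", "measured", "known", "first", "only" and "open" are said of these compounds alone.

Of the compounds shown here, three built on one shared core have been measured in a functional assay on THP-1 cells (Homo sapiens) for inhibition, read by ELISA, with stated times of 1 h and 18 h; a higher number here means a weaker inhibitor, a lower number a stronger inhibitor. Compound 1 `Cc1cnc(Nc2cccc(C(=O)N3CCCC3)c2)nc1N[C@H]1[C@@H](C(N)=O)[C@@H]2C=C[C@H]1C2` gives 100 nM in this assay. Compound 2 `NC(=O)[C@@H]1[C@H](Nc2nc(Nc3cccc(C(=O)N4CCCC4)c3)ncc2-c2ccccc2)[C@H]2C=C[C@@H]1C2` gives 220 nM, and compound 3 `NC(=O)[C@@H]1[C@H](Nc2nc(Nc3cccc(C(=O)N4CCCC4)c3)ncc2-c2cccc(F)c2)[C@H]2C=C[C@@H]1C2` gives 870 nM. Compound 3 thus stands highest of the three numbers, which makes it the weakest inhibitor of the group, with compound 2 nearest and compound 1 furthest from it. The measured steps all concern one aromatic carbon of the core: phenyl in place of methyl brought a 2.2-fold higher number from compound 1 to compound 2 (0.34 log units; beyond the scatter), 3-fluorophenyl in place of methyl brought an 8.7-fold higher number from compound 1 to compound 3 (0.94 log units; beyond the scatter), and fluoro in place of hydrogen on an aromatic carbon brought a 4.0-fold higher number from compound 2 to compound 3 (0.60 log units; beyond the scatter). Compound 4 `NC(=O)[C@@H]1[C@H](Nc2nc(Nc3cccc(C(=O)N4CCCC4)c3)ncc2-c2ccnc(F)c2)[C@H]2C=C[C@@H]1C2` differs from compound 3 in one place: 2-fluoropyridin-4-yl in place of 3-fluorophenyl on an aromatic carbon. Among the measured compounds shown here, none of the measured steps exchanges a ring carbon for a ring nitrogen at this position, so the three steps bear on it only loosely; they show that altering the group here moves the number by a modest amount, and the fluorine is kept. A step within the usual scatter, or a modest one in either direction, is therefore expected: a 1.2-fold lower number from compound 3 to compound 4 (0.09 log units; within the scatter). Compound 4 is estimated at 700 nM, with a likely range from 250 nM to 2000 nM.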

Compound 4, half-maximal inhibitory concentration: 100 nM
Compound 4: the middle estimate sits 7.0-fold (0.85 log units) above what was measured; measured number below the stated range.
By their numbers in this assay, from the lowest: compounds 1 and 4 (each within the scatter of the next); then compound 2; then compound 3.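

Swapping one ring carbon for a ring nitrogen, with the fluorine kept, is a large change at this position on the pyrimidine-like part of the shared core: going to 2-fluoropyridin-4-yl gives a clear gain in inhibition (an 8.7-fold lower number from compound 3 to compound 4 (0.94 log units; beyond the scatter)). The earlier compounds shown here showed only rising numbers as methyl gave way to phenyl and then to 3-fluorophenyl, but that rise does not hold for every aromatic ring, since the 2-fluoropyridin-4-yl group also improves on phenyl (a 2.2-fold lower number from compound 2 to compound 4 (0.34 log units; beyond the scatter)) and matches methyl (no change at the digits printed from compound 1 to compound 4 (within the scatter)). A fluorinated six-membered aromatic ring can therefore sit at this position with no loss against the small methyl group, and the ring's hetero atom decides the outcome for this pair, where compound 3 alone had suggested that the fluorine carried a cost.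

Nothing shown here explains why the ring nitrogen has this effect. Also open, from the compounds shown here alone, is how a plain pyridin-4-yl ring, or one carrying an amine in place of the fluorine, would compare in this assay.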